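The source may report more compounds than this note shows. Statements on the series, on what has been measured and on what is new or still open speak of the compounds shown alone.

Measured compounds in a functional assay on HT-29 cells (Homo sapiens) for inhibition, read by MTT assay, tested at 100 uM; on this read-out lower numbers stand for less inhibition and higher numbers for more inhibition at the one concentration tested (going by the name of the read-out):

- compound 1, `O[C@H]1CCN(c2nc(Nc3cccc4c3CCCC4)c3ccccc3n2)C1`, gives 86.1%
- compound 2, `Oc1cccc(Nc2nc(NCc3ccccc3)c3ccccc3n2)c1`, gives 81.9%
- compound 3, `CN(C)CCNc1nc(-c2ccc(C(C)(C)C)cc2)nc2ccccc12`, gives 93.4%

Of the three numbers, compound 2 has the lowest. Its nearest neighbour is compound 1, whose value sits higher by an amount within the scatter, so the two cannot be told apart on this assay. Compound 3 sits further off, its value higher than that of compound 2 by an amount beyond the scatter. Among the compounds with values here, no pair of these three compounds differs in only one place, so none of the three gaps can be tied to a single structural change.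

Compound 4, `Fc1ccc(Nc2nc(NCc3ccccc3)c3ccccc3n2)cc1`, has not yet been measured. It stands next to compound 2 with one difference: 4-fluorophenyl in place of 3-hydroxyphenyl on a nitrogen on an aromatic ring. Cut one bond further out, the same difference reads (3-hydroxyphenyl)amino to (4-fluorophenyl)amino. Within the data shown here, no measured step of this kind exists in the set, so the direction rests on nothing more than the spread of the three measured values, which all lie high at the single concentration tested. The expected step from compound 2 to compound 4, a number 3.9 percentage points lower from compound 2 to compound 4 (within the scatter), is small and within the scatter, with no clear direction. Compound 4 is therefore estimated at 78%, expected to lie between 60% and 92%.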

Compound 4, a percentage reported as inhibition, at one concentration (the size of the read-out at that concentration, not a potency): 93.4%
Beside the measured number, compound 4's estimate is 15.4 percentage points below it, outside the stated range (above it).
By their numbers in this assay, from the lowest: compounds 2, 1, 3 and 4 (each within the scatter of the next, the first and the last beyond it).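

In this assay, the series now has its first step tied to a single place: 4-fluorophenyl in place of 3-hydroxyphenyl on a nitrogen on an aromatic ring gives a number 11.5 percentage points higher from compound 2 to compound 4 (beyond the scatter) and so lies beyond the usual scatter. This shows that the group at this position can shift the read-out even where all values lie high, and that in this pair the hydroxyl-bearing group, with its 1 hydrogen-bond donor and 1 hydrogen-bond acceptor, is not needed to reach this level of inhibition at the one concentration tested, since the entering group counts 0 of each. The step is a single reading at one concentration rather than a measure of potency, and no available measurement bears on why it occurs.

Going by these compounds, the two groups differ in both the substituent and its numbered place on the phenyl ring, so it remains open whether the step follows the fluorine, the loss of the hydroxyl or the change of place, a question that unsubstituted phenyl, 3-fluorophenyl and 4-hydroxyphenyl at this position would help to separate. On these data alone, how larger changes would read here also remains open, for example a phenyl ring carrying a carboxylic acid or a dimethylamino group.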